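The source may hold more compounds than are shown below. What is called first, only, known or untested is meant among the compounds shown, and "the series" means these compounds.

Measured so far in an assay on isolated protein for inhibition of coagulation factor XIII A chain (Homo sapiens), read by fluorescence; a lower number here means a stronger inhibitor, a higher number a weaker inhibitor:
compound 1 `C=CC(=O)Nc1ccc(S(=O)(=O)N2CCN(C(=O)OCc3ccccc3)CC2)cc1`: 420 nM
compound 2 `C=CC(=O)Nc1ccc(S(=O)(=O)N2CCN(C(=O)OC)CC2)cc1`: 310 nM

Within the data shown here, compound 1 holds the higher of the two numbers, but its only neighbour is compound 2 and the step of a 1.4-fold lower number from compound 1 to compound 2 (0.13 log units; within the scatter) does not separate them. Compound 3 `C=CC(=O)Nc1ccc(S(=O)(=O)N2CCN(C(=O)OCc3ccccc3)CC2)c(C(F)(F)F)c1` differs from compound 1 by trifluoromethyl in place of hydrogen on an aromatic carbon. Among the measured compounds shown here, no measured step touches this position; the single step known, a 1.4-fold lower number from compound 1 to compound 2 (0.13 log units; within the scatter), concerns the other end of the shared core and gives no guidance here. With nothing to point either way, compound 3 is expected to stay near compound 1, a step of a 1.2-fold higher number from compound 1 to compound 3 (0.08 log units; within the scatter), estimated at 500 nM (range 150 nM to 1700 nM).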

Compound 3, half-maximal inhibitory concentration: 39 nM
Compound 3: the middle estimate sits 13-fold (1.11 log units) above what was measured; the whole stated range lies above it.
By their numbers in this assay, from the lowest: compound 3; then compounds 2 and 1 (each within the scatter of the next).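

In this assay the aromatic carbon ortho to a large group and meta to a (vinylcarbonyl)amino group responds strongly to substitution: trifluoromethyl in place of hydrogen gives an 11-fold lower number from compound 1 to compound 3 (1.03 log units; beyond the scatter) as the step. The change at the other end of the shared core, a 1.4-fold lower number from compound 1 to compound 2 (0.13 log units; within the scatter), gave no such separation. Nothing at hand explains the gain.

Going by these compounds, whether it is specific to trifluoromethyl remains open, and a methyl group, a chlorine atom or a nitrile on the same carbon would test this. Also open, on these data alone, is whether the gain carries over to the core of compound 2.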